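The source may hold more compounds than are shown below. What is called first, only, known or untested is meant among the compounds shown, and "the series" means these compounds.

Within the data shown here, compound 1 `CCC(/C=C1\OC(=O)NC1=O)(CC)c1ccc(-c2ccc3cccc(F)c3c2)[nH]c1=O` is the one member of this set for which a number has been obtained. In a functional assay on CHO cells for antagonist activity at prostaglandin E2 receptor EP3 subtype (Homo sapiens), read by cAMP accumulation, with a stated time of 30 min (on this read-out higher numbers stand for weaker inhibition and lower numbers for stronger inhibition), compound 1 gives 61 nM. Two further members of the same series carry no result: in this assay compound 2 `CCC(/C=C1\OC(=O)NC1=O)(CC)c1ccc(-c2ccc3cccc(C(C)C)c3c2)[nH]c1=O` gives "not determined" (no result reported), and in this assay compound 3 `CCC(/C=C1\OC(=O)NC1=O)(CC)c1ccc(-c2ccc3cccc(C(F)(F)F)c3c2)[nH]c1=O` gives "not determined" (no result reported). Nothing can be said of where these two stand, and compound 1 stands alone as the reference point.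

Compound 4 `CCC(/C=C1\OC(=O)NC1=O)(CC)c1ccc(-c2ccc3cc(F)cc(F)c3c2)[nH]c1=O` differs from compound 1 in a single place: fluoro in place of hydrogen on an aromatic carbon. Among the measured compounds shown here, no pair of measured compounds in this set differs in one place. For the measured compounds named here, there is no measured step from which the size of this change can be read. The expectation therefore rests on the structure alone: a second fluoro entering the same ring system of the shared core, with no change in donors, acceptors or charge, is expected to move the read-out little, and the step from compound 1 to compound 4 is estimated to be a 1.0-fold lower number from compound 1 to compound 4 (0.01 log units; within the scatter), which is within the usual scatter of repeated measurements and does not favour one direction over the other.

On this basis compound 4 is expected to give in this assay about 60 nM, with the likely range running from 25 nM to 150 nM.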

Compound 4, half-maximal inhibitory concentration: 45 nM
The estimate for compound 4 lay 1.3-fold (0.12 log units) above the measured number; measured number inside the range.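

In this assay, the series now has its first measured step: fluoro in place of hydrogen on an aromatic carbon, meta to a fluoro group, gives a 1.4-fold lower number from compound 1 to compound 4 (0.13 log units; within the scatter). The earlier compounds shown here could not show that this carbon takes a fluoro without the two compounds being separated on this read-out, and no direction can be claimed for the change, so compound 4 simply joins compound 1 as a second compound with a measured antagonist value. No measurement is available that would explain this result or connect it to any property of the added fluoro.

From the compounds shown here alone, what a larger or different group would do on this same aromatic carbon stays open, since one step from hydrogen to fluoro says nothing about a methoxy group, an amine or a carboxylic acid there. Going by these compounds, compound 2, with its isopropyl group, and compound 3, with its trifluoromethyl group, still carry no number, so their steps from compound 1 cannot be read, and the effect of replacing the first fluoro remains unknown.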